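This account rests on a few compounds, and the source may have more. Where it says the series, first, only, none or still open, it means among the compounds named here.

Of the compounds shown here, three have been measured in a functional assay on the whole organism for inhibition, with Rattus norvegicus as the target, read by ELISA, with stated times of 30 min and 6 h, at a dose of 30 mg/kg by the oral route; a higher number here means more inhibition at the dose given (going by the name of the read-out), a lower number less inhibition. Compound 1 `N=c1sc(=S)[nH]c2c1cc(-c1ccc(Cl)cc1)n2-c1ccccc1` gives 2%. Compound 2 `CCC(C)Sc1nc2c(cc(-c3ccccc3)n2-c2ccccc2)c(=N)s1` gives 50%. Compound 3 `CCn1c(=S)[nH]c2c(cc(-c3ccccc3)n2-c2ccccc2)c1=N` gives 65%, the highest of the three numbers; the nearest to it is compound 2, at a distance beyond the scatter, and the furthest is compound 1, also beyond the scatter. Going by the values given here, no two of the measured compounds differ in one place only, so no single step has been isolated. Compound 1 bears the 4-chlorophenyl that compound 4 also bears, but it differs from compound 3 in other places too, so its low number cannot be attributed to the chloro alone.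

Compound 4 `CCn1c(=S)[nH]c2c(cc(-c3ccc(Cl)cc3)n2-c2ccccc2)c1=N` has not yet been measured. Relative to compound 3 the change is chloro in place of hydrogen on an aromatic carbon. A moderate step downward in this assay is expected, tempered by the fact that compound 1 gives 2% while carrying the same 4-chlorophenyl. Compound 4 is expected to give 50%, within 20% to 75%. The step expected from compound 3 to compound 4 is a number 15 percentage points lower from compound 3 to compound 4 (beyond the scatter).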

Compound 4, a percentage reported as inhibition, in the whole organism at one dose (the size of the read-out at that dose, not a potency): 61%
Estimate against measurement, compound 4: 11 percentage points below; low and high end bracket the measured number.
By their numbers in this assay, from the lowest: compound 1; then compound 2; then compounds 4 and 3 (each within the scatter of the next).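

Going by these compounds alone, this is the first single-place step: in this assay, chloro in place of hydrogen on the aromatic carbon para to a large group gives a number 4 percentage points lower from compound 3 to compound 4 (within the scatter). On the core of compound 3, phenyl and 4-chlorophenyl are therefore not told apart by this read-out at this dose, and this position accepts a chlorine atom with inhibition retained. Nothing on hand bears on what lies behind this result.

Open, from the compounds shown here alone, is whether a methoxy group, an amine or a carboxylic acid at the same position would stand level with hydrogen and chloro as well. Also open, going by these compounds, is whether the same step reads alike on the cores of compound 1 and compound 2, which each differ from compound 3 in more than one place.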